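A few compounds are considered here, and "the series" means these few. Any claim that something is new, unique, unknown or untested is made for them only; others in the source may bear on it.

Measured so far:
compound 1 `CC1(C)CC(=O)C(C(=S)SCc2ccccc2)=C(Nc2ccc(Cl)cc2)C1` — in a functional assay on PBMC cells (Homo sapiens) for inhibition, read by ELISA, with a stated time of 18 h (a lower number here means a stronger inhibitor, a higher number a weaker inhibitor), compound 1 gives > 20 ug/mL, which is a limit of the assay.
compound 2 `CCCCSC(=S)C1=C(Nc2ccc(Br)cc2)CC(C)(C)CC1=O` — in this assay compound 2 gives > 20 ug/mL, again a limit of the assay.

For the measured compounds named here, compound 2 therefore stands at the limit itself, and the only other value on the series sits at the same place: the limit of > 20 ug/mL in this assay, at which 2 of the 2 values shown sit. No number inside the measured window exists, and nothing separates the two compounds from each other.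

Compound 3 `CC1(C)CC(=O)C(C(=S)SCc2ccccc2)=C(Nc2ccc(Br)cc2)C1` differs from compound 2 in one place: phenyl in place of propyl on a saturated chain carbon bound to a sulfur. The same benzylsulfanyl group is already present in compound 1, whose result is the limit > 20 ug/mL, so both neighbours of compound 3 end at the limit. No step beyond the scatter is expected from compound 2 to compound 3; the expected move a step that the limit leaves unreadable from compound 2 to compound 3 is essentially none. For compound 3 the expected outcome in this assay is again a limit; if a number is obtained, it is estimated at 25 ug/mL, in the range 12 ug/mL to 60 ug/mL.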

Compound 3, half-maximal inhibitory concentration: > 20 ug/mL
Compound 3: no number, only a limit; the forecaster's own chance of this, stated with the estimate: 80%; the middle value does not contradict the limit.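

No step can be read in this assay between compound 3 and either compound 1 or compound 2, as all three end at a limit of the assay: the limit of > 20 ug/mL in this assay, at which 3 of the 3 values shown sit.

In this assay the compounds shown leave open whether butylsulfanyl versus benzylsulfanyl, or bromo versus chloro, changes inhibition at all.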